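The source may hold more compounds than are shown below. What is called first, only, known or untested is meant among the compounds shown, and "the series" means these compounds.

The measured compounds:
Compound 1, `C/C=C/C(=O)N(Cc1cccc(O)c1)c1cc(OC)c(OC)c(OC)c1`, gives 6700 nM in a functional assay on HCT-116 cells (Homo sapiens) for inhibition, read by MTT assay, with a stated time of 48 h; on this read-out lower numbers stand for stronger inhibition and higher numbers for weaker inhibition.
Compound 2, `C/C=C/C(=O)N(Cc1ccc(OC)c([N+](=O)[O-])c1)c1cc(OC)c(OC)c(OC)c1`, gives 670 nM in this assay.
Compound 3, `C/C=C/C(=O)N(Cc1ccc(OC)cc1)c1cc(OC)c(OC)c(OC)c1`, gives 500 nM in this assay.

Compound 3 has the lowest of the three numbers. Its gap to compound 2 is small: a 1.3-fold lower number from compound 2 to compound 3 (0.13 log units; within the scatter), so these two cannot be ordered. Its gap to compound 1 is large: a 13-fold lower number from compound 1 to compound 3 (1.13 log units; beyond the scatter), which goes with a different substitution pattern on the benzyl ring rather than a single added group.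

The next compound, compound 4, is `C/C=C/C(=O)N(Cc1ccc(OC)c(F)c1)c1cc(OC)c(OC)c(OC)c1`. It differs from compound 3 in one place: fluoro in place of hydrogen on an aromatic carbon. Of the known steps, a 1.3-fold lower number from compound 2 to compound 3 (0.13 log units; within the scatter) is the one that speaks to this change. There the same aromatic carbon carries either nitro or hydrogen and the number stays within the scatter; a group at this position thus appears to be tolerated. The step of a 13-fold lower number from compound 1 to compound 3 (1.13 log units; beyond the scatter) alters the ring pattern more broadly and says little about a single fluoro. No step beyond the scatter is therefore expected, in either direction. For compound 4 the expected step is a 1.1-fold lower number from compound 3 to compound 4 (0.05 log units; within the scatter). Compound 4 is estimated at 450 nM, with a range from 150 nM to 1400 nM.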

Compound 4, half-maximal inhibitory concentration: 1160 nM
The estimate for compound 4 lay 2.6-fold (0.41 log units) below the measured number; low and high end bracket the measured number.
By their numbers in this assay, from the lowest: compounds 3, 2 and 4 (each within the scatter of the next, the first and the last beyond it); then compound 1.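

In this assay, the step of a 2.3-fold higher number from compound 3 to compound 4 (0.37 log units; beyond the scatter) shows that this aromatic carbon, ortho to a methoxy group, is not indifferent to what it carries: even a single fluoro atom in place of hydrogen moves the number beyond the scatter, which the nitro comparison alone had not suggested. The step of a 1.7-fold higher number from compound 2 to compound 4 (0.24 log units; within the scatter) stays within the scatter, so fluoro and nitro cannot be ordered here, and compound 2 cannot be separated from either compound 3 or compound 4, even though those two can be separated from each other. The step of a 5.8-fold lower number from compound 1 to compound 4 (0.76 log units; beyond the scatter) shows that the 3-fluoro-4-methoxyphenyl group still gives a clearly lower number than the 3-hydroxyphenyl group, so adding fluoro does not remove the advantage over compound 1.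

Nothing available here explains why fluoro raises the number relative to hydrogen. The compounds shown also leave open what a chloro group or an amine would do on this same aromatic carbon, and whether fluoro on a different carbon of this ring would give a step of similar size.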